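Amide variation on a chalcone series in cell inhibition

The source may report more compounds than this note shows. Statements on the series, on what has been measured and on what is new or still open speak of the compounds shown alone.

Measured so far:
compound 1 `COc1cc(/C=C/C(=O)c2cccc(NC(=O)c3ccc(Cl)c(Cl)c3)c2)ccc1O`: 29.5 ug/mL
compound 2 `COc1cc(/C=C/C(=O)c2cccc(NC(=O)C(C)C)c2)ccc1O`: 8.31 ug/mL
compound 3 `COc1cc(/C=C/C(=O)c2cccc(NC(=O)c3cc(Cl)cc(Cl)c3)c2)ccc1O`: only a limit, > 50 ug/mL

Compound 3 stands at the limit of a functional assay on U-87MG ATCC cells (Homo sapiens) for inhibition; on this read-out higher numbers stand for weaker inhibition and lower numbers for stronger inhibition (the limit of > 50 ug/mL in this assay, at which 1 of the 3 values shown sits), so its number is not known beyond that bound. Compound 4 `CCCC(=O)Nc1cccc(C(=O)/C=C/c2ccc(O)c(OC)c2)c1` differs from compound 3 by propyl in place of 3,5-dichlorophenyl on a carbonyl carbon. Within the data shown here, two measured steps bear on this change: an at least 6.0-fold higher number from compound 2 to compound 3 (0.77 log units; beyond the scatter) and a 3.5-fold lower number from compound 1 to compound 2 (0.55 log units; beyond the scatter). Both put the isopropyl amide at a lower number than either dichlorophenyl amide. Propyl is a chain, like isopropyl, so the reverse of the second step is expected here: an at least 5.0-fold lower number from compound 3 to compound 4 (0.69 log units; beyond the scatter). Compound 4 is therefore estimated at 10 ug/mL in this assay, within a range from 4 ug/mL to 25 ug/mL.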

Compound 4, half-maximal inhibitory concentration: 5.56 ug/mL
For compound 4 the middle estimate is 1.8-fold (0.25 log units) above the measured one, and the stated range covers the measured number.
By their numbers in this assay, from the lowest: compounds 4 and 2 (each within the scatter of the next); then compound 1. At a limit, above all of these: compound 3.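

Compound 3 stands only at a limit: the limit of > 50 ug/mL in this assay, at which 1 of the 4 values shown sits.

Read against that limit, an at least 8.9-fold lower number from compound 3 to compound 4 (0.95 log units; beyond the scatter), and a 5.3-fold lower number from compound 1 to compound 4 (0.72 log units; beyond the scatter), so in this assay the propyl amide joins the isopropyl amide on the low side of both dichlorophenyl amides. Between the two chains, a 1.5-fold lower number from compound 2 to compound 4 (0.17 log units; within the scatter), so straight and branched cannot be told apart at this position.

Still open, on these data alone, is whether a longer chain such as hexyl keeps these numbers, and whether a cyclohexyl group reads like the chains or like the dichlorophenyl amides. An unsubstituted phenyl amide would separate the part played by the ring from that of the chlorines.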